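The compounds below may be only part of what the source reports. "The series", "measured", "known", "first", "only" and "open" are said of these compounds alone.

Measured so far: compound 1, `CCOC(=O)c1cccc(-c2ccc(OCC)cc2)c1`, gives 50000 nM in an assay on COS-7 cells for inhibition of patatin-like phospholipase domain-containing protein 2 (Mus musculus); a lower number here means a stronger inhibitor, a higher number a weaker inhibitor. Compound 2, `CCOc1ccc(-c2cccc([N+](=O)[O-])c2)cc1`, gives in this assay only a limit, > 200000 nM.

Compound 2 thus stands at the weak end of the two values shown, where only a limit is reported, as stated in the limit of > 200000 nM in this assay, at which 1 of the 2 values shown sits. Compound 3, `CCOc1ccc(-c2cccc(NC(=O)N(C)C)c2)cc1`, differs from compound 2 by (dimethylcarbamoyl)amino in place of nitro on an aromatic carbon. Among the compounds with values here, only one measured step exists, an at least 4.0-fold higher number from compound 1 to compound 2 (0.60 log units; beyond the scatter), and it concerns a different exchange, nitro in place of ethoxycarbonyl, so it does not bear directly on the change from nitro to (dimethylcarbamoyl)amino; it shows only that a change at this position can move the number beyond the scatter. Within the data shown here, with no measured step for this exchange, the expectation for compound 3 is loose: the number for compound 3 is estimated at 20000 nM, within 3000 nM to 100000 nM, which would mean an expected step of an at least 10-fold lower number from compound 2 to compound 3 (1.00 log units; beyond the scatter).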

Compound 3, half-maximal inhibitory concentration: 70000 nM
Beside the measured number, compound 3's estimate is 3.5-fold (0.54 log units) below it, within the range that was stated.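

The exchange shows that the loss seen with nitro at this aromatic carbon is not a general feature of the position: an at least 2.8-fold lower number from compound 2 to compound 3 (0.45 log units; beyond the scatter) in this assay. The larger (dimethylcarbamoyl)amino group and the ethoxycarbonyl group cannot be told apart here, with a 1.4-fold higher number from compound 1 to compound 3 (0.15 log units; within the scatter), so two quite different groups give matching results and nitro alone stands apart among the three. On these data alone, the figure for compound 2 is only a limit, so the true size of the step from it stays unknown: the limit of > 200000 nM in this assay, at which 1 of the 3 values shown sits.

The compounds shown leave open whether an amine or a carboxylic acid at this aromatic carbon would give a number that differs from those of compound 1 and compound 3. They also leave open whether a longer chain in place of the ethoxy group on the shared core would move the number.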